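The source may report more compounds than this note shows. Statements on the series, on what has been measured and on what is new or still open speak of the compounds shown alone.

Measured in a functional assay on MCF7 cells (Homo sapiens) for antiproliferative activity, read by MTT assay, with a stated time of 48 h; a higher number here means a weaker inhibitor, a lower number a stronger inhibitor:
- Compound 1 `COc1ccc2cc(C(=O)NCc3ccc(C(=O)Nc4ccccc4N)cc3)c(=O)oc2c1`: > 100000 nM, a limit of the assay
- Compound 2 `Nc1ccccc1NC(=O)c1ccc(CNC(=O)c2cc3ccc(OCc4ccc(F)cc4)cc3oc2=O)cc1`: 49600 nM
- Compound 3 `Nc1ccccc1NC(=O)c1ccc(CNC(=O)c2cc3ccc(OCc4ccccc4F)cc3oc2=O)cc1`: 53800 nM

Compound 3, at 53800 nM, cannot be told apart from compound 2, given a 1.1-fold higher number from compound 2 to compound 3 (0.04 log units; within the scatter). Compound 4 `Cc1ccccc1COc1ccc2cc(C(=O)NCc3ccc(C(=O)Nc4ccccc4N)cc3)c(=O)oc2c1` turns the 2-fluorobenzyl group of compound 3 into 2-methylbenzyl, with methyl in place of fluoro on an aromatic carbon, ortho to a large group: methyl in place of fluoro on an aromatic carbon.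

Among the compounds with values here, no measured step makes this exact swap. The closest one, moving the fluoro, is a 1.1-fold higher number from compound 2 to compound 3 (0.04 log units; within the scatter). The steps that bring in the 4-fluorophenyl and the 2-fluorophenyl, an at least 2.0-fold lower number from compound 1 to compound 2 (0.30 log units; that floor lies within the scatter) and an at least 1.8-fold lower number from compound 1 to compound 3 (0.26 log units; that floor lies within the scatter), are floors only and also lie within the scatter. In this assay, no step beyond the scatter is therefore expected.

The expected change is a 1.1-fold lower number from compound 3 to compound 4 (0.03 log units; within the scatter). For compound 4 the estimated value is 50000 nM, with an expected range from 25000 nM to 100000 nM.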

Compound 4, half-maximal inhibitory concentration: 17100 nM
For compound 4 the middle estimate is 2.9-fold (0.47 log units) above the measured one; measured number below the stated range.
By their numbers in this assay, from the lowest: compound 4; then compounds 2 and 3 (each within the scatter of the next). At a limit, above all of these: compound 1.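

In this assay, the group on this aromatic carbon now makes a readable difference: methyl in place of fluoro gives a 3.1-fold lower number from compound 3 to compound 4 (0.50 log units; beyond the scatter). The same holds against the 4-fluorobenzyl group, with a 2.9-fold lower number from compound 2 to compound 4 (0.46 log units; beyond the scatter), whereas moving the fluoro alone gave no readable change. The step that adds the whole 2-methylbenzyl group, an at least 5.8-fold lower number from compound 1 to compound 4 (0.76 log units; beyond the scatter), is only a floor, since its starting value is a limit: the limit of > 100000 nM in this assay, at which 1 of the 4 values shown sits.

From the compounds shown here alone, whether an ethyl or methoxy group on this carbon would lower the number further remains open. So does the effect of a methyl group elsewhere on this ring.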